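Notes on the step from compound 3 to compound 4

The source may report more compounds than this note shows. Statements on the series, on what has been measured and on what is new or still open speak of the compounds shown alone.

Measured in an ADME assay on Huh-7 cells (Homo sapiens) for cytotoxicity, with a stated time of 72 h; a lower number here means that less compound is tolerated, a higher number that more compound is tolerated (as reported)
- compound 1 `CC(C)CCn1nc(-c2cccs2)c(O)c(C2=NS(=O)(=O)c3cc(N(C(C)C)S(C)(=O)=O)ccc3N2)c1=O` gives "not determined" (no result reported)
- compound 2 `CC(C)CCn1nc(-c2cccs2)c(O)c(C2=NS(=O)(=O)c3cc(CS(C)(=O)=O)ccc3N2)c1=O` gives > 33000 nM
- compound 3 `COC(C)(C)CCn1nc(-c2cccs2)c(O)c(C2=NS(=O)(=O)c3cc(NS(C)(=O)=O)ccc3N2)c1=O` gives > 33000 nM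

Compound 3 in this assay gives > 33000 nM as a limit of the assay and not as a number. Compound 2 gives > 33000 nM as a limit too. Compound 1 has no reported result. Going by the values given here, the series so far amounts to the limit of > 33000 nM in this assay, at which 2 of the 3 values shown sit, and holds no measured step.

Compound 4 `CS(=O)(=O)Nc1ccc2c(c1)S(=O)(=O)N=C(c1c(O)c(-c3cccs3)nn(CC3(C(F)(F)F)CCC3)c1=O)N2` differs from compound 3 in one place, with 1-(trifluoromethyl)cyclobutyl in place of 2-methoxy-2-methylpropyl on a saturated chain carbon bound to an aromatic nitrogen. Cut one bond further out, the same difference reads 3-methoxy-3-methylbutyl to (1-(trifluoromethyl)cyclobutyl)methyl.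

Among the compounds with values here, no measured step is available to size this change in this assay, so the expectation starts from the limit of compound 3 (> 33000 nM) alone. The expected step is a number no higher from compound 3 to compound 4 (the limit leaves the size open) and it is not expected to go beyond the scatter in either direction. Compound 4 is estimated at 33000 nM with an expected range from 14000 nM to 50000 nM and a report as a limit is the likeliest outcome.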

Compound 4, half-maximal cytotoxic concentration: > 1000 nM
Compound 4 gave a limit, no number; the forecaster's own chance of this, stated with the estimate: 70%; the middle value lies beyond the limit too.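

In this assay compound 3 and compound 4 both stand as limits of the assay and not as numbers, and no step can be read between them. The compounds shown leave open whether 1-(trifluoromethyl)cyclobutyl in place of 2-methoxy-2-methylpropyl changes the half-maximal cytotoxic concentration at all, and by how much.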